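The compounds below may be only part of what the source reports. "The series", "measured", "known", "first", "only" and "open" are said of these compounds alone.

Measured in a physicochemical assay for solubility, with a stated time of 1 h, at 37 degrees C, at pH 6.8; on this read-out lower numbers stand for lower solubility and higher numbers for higher solubility:
- compound 1 `Nc1ncnc2c1nc(NCc1ccc(-c3ccccc3)cc1)n2[C@@H]1O[C@H](CO)[C@@H](O)[C@H]1O`: 3 ug/mL
- compound 2 `CCOc1cc(CNc2nc3c(N)ncnc3n2[C@@H]2O[C@H](CO)[C@@H](O)[C@H]2O)ccc1-c1ccccc1`: 121 ug/mL

Compound 1 stands lowest of the two numbers. Compound 3 `CCOc1cc(-c2ccccc2)ccc1CNc1nc2c(N)ncnc2n1[C@@H]1O[C@H](CO)[C@@H](O)[C@H]1O` differs from it by ethoxy in place of hydrogen on an aromatic carbon, with ethoxy in place of hydrogen on an aromatic carbon, ortho to a large group and meta to a phenyl group. Going by the values given here, one measured step bears on this: a 40-fold higher number from compound 1 to compound 2 (1.61 log units; beyond the scatter), a large step for the same exchange on another aromatic carbon. That single example leaves open how far the step carries to a new place, so a smaller step in the same direction is expected in this assay. The expected step is an 8.3-fold higher number from compound 1 to compound 3 (0.92 log units; beyond the scatter). The estimate for compound 3 is 25 ug/mL, with an expected range of 6 ug/mL to 100 ug/mL.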

Compound 3, solubility: 2 ug/mL
Compound 3: the middle estimate sits 13-fold (1.10 log units) above what was measured; the measured number lies below the stated range.
By their numbers in this assay, from the lowest: compounds 3 and 1 (each within the scatter of the next); then compound 2.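

In this assay ethoxy in place of hydrogen on this aromatic carbon, ortho to a large group and meta to a phenyl group, gives a 1.5-fold lower number from compound 1 to compound 3 (0.18 log units; within the scatter) and so no readable change. The large step of a 40-fold higher number from compound 1 to compound 2 (1.61 log units; beyond the scatter) for the same exchange on another aromatic carbon therefore does not carry over to this place. Nothing at hand accounts for the contrast between the two places. Going by these compounds, whether methoxy, a longer chain such as propoxy or an amine on this carbon would behave like ethoxy stays open, as does whether those groups would show the same contrast between the two places.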